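A few compounds are considered here, and "the series" means these few. Any claim that something is new, unique, unknown or untested is made for them only; others in the source may bear on it.

Compound 1 `CC(C)(C)NS(=O)(=O)c1cccc(NC(=O)c2cccnc2N2CCC3(CC2)CC3)c1` gives the highest number of the three compounds measured in a functional assay on OVCAR-3 cells (Homo sapiens) for antiproliferative activity; a higher number here means that more compound is needed for the effect, a lower number that less compound is needed: compound 1 gives 840 nM. Compound 2 `CC(C)(C)NS(=O)(=O)c1cccc(NC(=O)c2ccc(NC(C)(C)CO)nc2N2CCC3(CC2)CC3)n1` gives 42 nM in this assay, and compound 3 `CC(C)(C)NS(=O)(=O)c1cccc(NC(=O)c2ccc(NC3(CO)CC3)cc2N2CCC3(CC2)CC3)n1` gives 62 nM. For the measured compounds named here, both of these gaps lie beyond the scatter, yet neither pair differs from compound 1 in a single place, so they show only that the shared core can reach considerably lower numbers with other substitution, not what any one exchange contributes. Compound 4 `O=C(Nc1cccc(S(=O)(=O)C2CCCC2)c1)c1cccnc1N1CCC2(CC1)CC2` differs from compound 1 in exactly one place: cyclopentyl in place of (tert-butyl)amino on a sulfonyl sulfur. Going by the values given here, no measured pair in this set isolates this exchange on the sulfonyl sulfur, so the expectation rests on the value of compound 1 alone. The step from compound 1 to compound 4 is expected to be modest, leaning toward a somewhat higher number, and is estimated as a 1.5-fold higher number from compound 1 to compound 4 (0.19 log units; within the scatter). On that basis compound 4 is expected to give 1300 nM in this assay, with a plausible range from 400 nM to 4000 nM.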

Compound 4, half-maximal effective concentration: 1240 nM
Compound 4: the middle estimate sits 1.0-fold (0.02 log units) above what was measured; measured number inside the range.
By their numbers in this assay, from the lowest: compounds 2 and 3 (each within the scatter of the next); then compounds 1 and 4 (each within the scatter of the next).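

In this assay, for the compounds shown here, the exchange of (tert-butyl)amino for cyclopentyl on a sulfonyl sulfur is the first single-place step in this set, and it reads as a 1.5-fold higher number from compound 1 to compound 4 (0.17 log units; within the scatter). On the core of compound 1, then, a group with a hydrogen-bond donor and no ring gives way to a carbon-only ring without a step beyond the scatter. No measurement at hand accounts for this outcome.

On these data alone, whether the exchange reads the same on the more substituted cores of compound 2 and compound 3 remains open. Also open, as far as these compounds go, is how other groups on the sulfonyl sulfur would behave, such as a methylamino group, a piperidine or a cyclohexyl ring.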